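Toward a 2-phenylcyclohexyl amide on the shared core

A few compounds are considered here, and "the series" means these few. Any claim that something is new, unique, unknown or untested is made for them only; others in the source may bear on it.

Compound 3 `CNC(=O)[C@@H]1C[C@H](n2cc(C3CC3)nn2)CN1C(=O)c1ccc(CN)c(OC)c1` carries a methyl on the amide-type nitrogen of the shared core. Within the data shown here, in an assay on isolated protein for inhibition of serine protease 1 (Homo sapiens), read by fluorescence (on this read-out higher numbers stand for weaker inhibition and lower numbers for stronger inhibition), compound 3 gives 2100 nM, the highest of the three numbers measured so far. Compound 1 `CNC(=O)[C@@H]1C[C@H](N2CCc3ccccc3C2)CN1C(=O)c1ccc(CN)c(OC)c1` gives 490 nM in this assay, and compound 2 `COc1cc(C(=O)N2C[C@@H](n3cc(C4CC4)nn3)C[C@H]2C(=O)N[C@H]2C[C@@H]2c2ccccc2)ccc1CN` gives 960 nM. Two single changes lead to compound 3: a 4.3-fold higher number from compound 1 to compound 3 (0.63 log units; beyond the scatter), and a 2.2-fold higher number from compound 2 to compound 3 (0.34 log units; beyond the scatter).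

Compound 4 `COc1cc(C(=O)N2C[C@@H](n3cc(C4CC4)nn3)C[C@H]2C(=O)N[C@H]2CCCC[C@@H]2c2ccccc2)ccc1CN` has not been measured. The change from compound 3 is 2-phenylcyclohexyl in place of methyl on an amide-type nitrogen. Among the measured compounds shown here, only one measured step bears on it, a 2.2-fold higher number from compound 2 to compound 3 (0.34 log units; beyond the scatter), which runs in the opposite direction and with a three-membered rather than a six-membered ring carrying the phenyl. Whether a 2-phenylcyclohexyl behaves like a 2-phenylcyclopropyl on this nitrogen is not shown by any measured pair, so the expectation rests on that single step alone. For compound 4 a modest step toward a lower number is therefore expected, a 2.1-fold lower number from compound 3 to compound 4 (0.32 log units; beyond the scatter), because a 2.2-fold higher number from compound 2 to compound 3 (0.34 log units; beyond the scatter) went the other way by a comparable amount. Compound 4 is estimated at 1000 nM in this assay, with a range from 400 nM to 2500 nM.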

Compound 4, half-maximal inhibitory concentration: 19 nM
Compound 4: middle estimate off by 53-fold (1.72 log units), on the high side; measured number outside the range, below it.
By their numbers in this assay, from the lowest: compound 4; then compounds 1 and 2 (each within the scatter of the next); then compound 3.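

In this assay, among these compounds, the amide-type nitrogen proves far more sensitive than the earlier compounds suggested: the one step seen there before was a 2.2-fold higher number from compound 2 to compound 3 (0.34 log units; beyond the scatter) and was modest, whereas 2-phenylcyclohexyl in place of methyl gives a 110-fold lower number from compound 3 to compound 4 (2.04 log units; beyond the scatter) and is large. A phenyl-bearing ring on this nitrogen is therefore not enough in itself, since 2-phenylcyclohexyl in place of 2-phenylcyclopropyl gives a 51-fold lower number from compound 2 to compound 4 (1.70 log units; beyond the scatter) and so the ring carrying the phenyl matters greatly in this pair. No measurement among those shown offers a reason for the size of these steps.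

The compounds shown leave open whether the phenyl is needed at all, which a plain cyclohexyl on this nitrogen would test, and whether a 2-phenylcyclopentyl would fall nearer compound 2 or compound 4. They also leave open whether the other stereoisomers of 2-phenylcyclohexyl behave alike, and whether the same step holds when 1,2,3,4-tetrahydroisoquinolin-2-yl replaces 4-cyclopropyl-1H-1,2,3-triazol-1-yl on the saturated ring carbon.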